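Series notes: the step from compound 2 to compound 4

The source may report more compounds than this note shows. Statements on the series, on what has been measured and on what is new or still open speak of the compounds shown alone.

Measured so far, in a functional assay on MGC-803 cells (Homo sapiens) for inhibition, read by MTT assay, with a stated time of 72 h; on this read-out lower numbers stand for stronger inhibition and higher numbers for weaker inhibition:
compound 1, `Cc1cc(Nc2cc(-c3ccccc3)[nH]n2)n2nc(SCc3c(Cl)cccc3Cl)nc2n1`, gives 5280 nM
compound 2, `Cc1cc(Nc2ccn(Cc3nc(C)c4ccccc4n3)n2)n2nc(SCc3ccc(Br)cc3)nc2n1`, gives 960 nM
compound 3, `Cc1cc(Nc2cc(-c3ccccc3)[nH]n2)n2nc(SCc3cccc4ccccc34)nc2n1`, gives 3120 nM

Compound 2 stands lowest of the three numbers: compound 3 lies a step beyond the scatter above it, compound 1 further still. Within the data shown here, compound 2 differs from compounds 1 and 3 in more than one place, so no single step reaches it from either.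

Among the measured compounds shown here, the only step measured within one place is a 1.7-fold lower number from compound 1 to compound 3 (0.23 log units; within the scatter). It sits on a saturated chain carbon bound to a sulfur, not where compound 4 changes, so it does not bear on the present step.

Compound 4, `Cc1cc(Nc2ccn(Cc3ccccc3)n2)n2nc(SCc3ccc(Br)cc3)nc2n1`, differs from compound 2 by phenyl in place of 4-methylquinazolin-2-yl on a saturated chain carbon bound to an aromatic nitrogen. For the measured compounds named here, no measured pair varies that position, so the direction of the step is open. Without a shown step at this place, the estimate for compound 4 is set close to compound 2, allowing a wide range upward: compound 4 is expected to give 1800 nM (range 600 nM to 5500 nM), an expected step of a 1.9-fold higher number from compound 2 to compound 4 (0.27 log units; within the scatter).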

Compound 4, half-maximal inhibitory concentration: 4720 nM
Estimate against measurement, compound 4: 2.6-fold (0.42 log units) below, within the range that was stated.
By their numbers in this assay, from the lowest: compound 2; then compounds 3, 4 and 1 (each within the scatter of the next).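

Among these compounds, the group on the saturated chain carbon bound to an aromatic nitrogen is the first place where a single change moves the number beyond the scatter: in this assay, phenyl in place of 4-methylquinazolin-2-yl gives a 4.9-fold higher number from compound 2 to compound 4 (0.69 log units; beyond the scatter). The change takes away one six-membered aromatic ring and both hydrogen-bond acceptors of the leaving group, and this one step cannot separate those differences. Nothing at hand explains the step.

A pyridin-2-yl or naphthalen-2-yl group on the same carbon would help separate the contribution of the ring nitrogens from that of the second ring. From the compounds shown here alone, whether the step holds when the rest of the molecule changes stays open, as it is read on one background only.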